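The compounds below may be only part of what the source reports. "The series", "measured", "known", "first", "only" and "open" are said of these compounds alone.

Three compounds of the series are in hand. Compound 1 `CCCOC(=O)/C=C(C)/C=C/CC(C)CCCC(C)C` gives 7.28 in a physicochemical assay for lipophilicity; a lower number here means a more polar compound, a higher number a more lipophilic compound. Compound 2 `CCCOC(=O)/C=C(C)/C=C/CC(C)CCCC(C)(C)OC` gives 6.08 in this assay, and compound 3 `CSC(=O)/C=C(C)/C=C/CC(C)CCCC(C)C` gives 7.44. The cores of compound 1 and compound 3 differ by methylsulfanyl in place of propoxy on a carbonyl carbon; the resulting step, a number 0.16 log units higher from compound 1 to compound 3 (within the scatter), stays within the scatter. The change from compound 1 to compound 2 is methoxy in place of hydrogen on a saturated chain carbon bound to three saturated chain carbons, and it made a number 1.20 log units lower from compound 1 to compound 2 (beyond the scatter). Compound 4 `COC(C)(C)CCCC(C)C/C=C/C(C)=C/C(=O)SC` is not yet measured; it differs from compound 3 by methoxy in place of hydrogen on a saturated chain carbon bound to three saturated chain carbons, the same change at the same place, occurring twice among these compounds. For compound 4 a step of a number 1.20 log units lower from compound 3 to compound 4 (beyond the scatter) in this assay is expected, resting on the single earlier case, a number 1.20 log units lower from compound 1 to compound 2 (beyond the scatter), and on the near-equal cores shown by a number 0.16 log units higher from compound 1 to compound 3 (within the scatter). Compound 4 is accordingly estimated at 6.24, between 5.85 and 6.65.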

Compound 4, partition coefficient: 6.24
Beside the measured number, compound 4's estimate shows no gap at the digits printed, within the range that was stated.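

Methoxy in place of hydrogen on a saturated chain carbon bound to three saturated chain carbons gives a number 1.20 log units lower from compound 3 to compound 4 (beyond the scatter) in this assay and so repeats a number 1.20 log units lower from compound 1 to compound 2 (beyond the scatter) on a second core; methylsulfanyl in place of propoxy on a carbonyl carbon gives a number 0.16 log units higher from compound 2 to compound 4 (within the scatter) with the methoxy present and a number 0.16 log units higher from compound 1 to compound 3 (within the scatter) without it, so the two changes add across these four compounds. This covers two cores and one place only, and it does not show that the step holds on any other core. Nothing on hand bears on the reason for the step.

From the compounds shown here alone, whether ethoxy or an amine at the same place gives a step of like size stays open. So does whether the methoxy step holds with a longer chain in place of propoxy, or with an amide at the carbonyl carbon.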